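Phenyl for Methyl on Sulfur Across Two Related Cores

The source may report more compounds than this note shows. Statements on the series, on what has been measured and on what is new or still open speak of the compounds shown alone.

Measured so far:
compound 1, `CNC1=C(SC)C(=O)c2ncccc2C1=O`, a limit of the assay: > 200000 nM
compound 2, `CNC1=C(Sc2ccccc2)C(=O)c2ncccc2C1=O`, a limit of the assay: > 150000 nM
compound 3, `CNC1=C(SC)C(=O)c2cccnc2C1=O`, a limit of the assay: > 200000 nM

All three compounds were tested in a functional assay on cells (Neutrophil, Homo sapiens) for inhibition, read by WST assay, with a stated time of 20 min (on this read-out higher numbers stand for weaker inhibition and lower numbers for stronger inhibition), and none of them gave a number; each value is a limit of the assay. Compound 1 and compound 2 differ by phenyl in place of methyl on a sulfur. The step between them, a step that the two limits leave unreadable from compound 1 to compound 2, cannot be read, since both values sit at limits: the limit of > 150000 nM in this assay, at which 1 of the 3 values shown sits, and the limit of > 200000 nM in this assay, at which 2 of the 3 values shown sit, describe where the three values stand. Compound 3 has the same atoms as compound 1 joined differently; the difference between the two cores is not broken down here.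

Compound 4, `CNC1=C(Sc2ccccc2)C(=O)c2cccnc2C1=O`, is not yet measured. It differs from compound 3 by phenyl in place of methyl on a sulfur, the same change as that from compound 1 to compound 2. Because compound 3 gives only a limit, > 200000 nM, and the matching measured step that the two limits leave unreadable from compound 1 to compound 2 is unreadable, compound 4 is expected to remain near the limit as well. The expected step of a number no higher from compound 3 to compound 4 (the limit leaves the size open) is therefore estimated as flat. In this assay compound 4 is estimated at 200000 nM, with a range from 100000 nM to 400000 nM.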

Compound 4, half-maximal inhibitory concentration: 92800 nM
Estimate against measurement, compound 4: 2.2-fold (0.33 log units) above; measured number outside the range, below it.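

In this assay, as far as these compounds go, phenyl in place of methyl on a sulfur gives an at least 2.1-fold lower number from compound 3 to compound 4 (0.33 log units; beyond the scatter), so on the core of compound 3 this change gives stronger inhibition, though the full size of the step stays open. Compound 3 gives only a limit of the assay, > 200000 nM. The same change on the core of compound 1 cannot be read, so the series does not show whether the effect carries from one core to the other, and the values there stay at limits: the limit of > 150000 nM in this assay, at which 1 of the 4 values shown sits.

The compounds shown leave open whether other groups on the sulfur, such as benzyl or a longer chain, would lower the number further than phenyl does. They also leave open whether a carboxylic acid or an amine on the phenyl ring would shift the result, and whether any such group would bring the core of compound 1 to a measurable number.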